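Shortening the Linker Chain from Compound 1 to Compound 3

The source may report more compounds than this note shows. Statements on the series, on what has been measured and on what is new or still open speak of the compounds shown alone.

Measured so far:
Compound 1 `C/C(=N/c1ccnc2cc(Cl)ccc12)NCCCCN1CCCCC1` — > 1 h
Compound 2 `CN(C)CCC/N=C(\c1ccccc1)N(CCCN(C)C)c1ccnc2cc(Cl)ccc12` — > 1 h

Both compounds were tested in an ADME assay (liver, Mus musculus) for metabolic stability, read by LC-MS, using microsomes, tested at 1 uM; a higher number here means that the compound lasts longer, a lower number that the compound disappears faster. For compound 1 the reading of > 1 h is a limit of the assay, not a number. For compound 2 the reading of > 1 h is likewise a limit. Compound 1 therefore stands at the limit of > 1 h in this assay, at which 2 of the 2 values shown sit, and the two measured compounds cannot be told apart on these readings.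

Compound 3 `C/C(=N/c1ccnc2cc(Cl)ccc12)NCCCN1CCCCC1` has not been measured in this assay. It differs from compound 1 by piperidin-1-yl in place of (piperidin-1-yl)methyl on a saturated chain carbon, three bonds along the chain from an amine nitrogen. Among the compounds with values here, no step between measured compounds is available to anchor a change of this kind, so only a guess can be made. The expected step that the limit leaves unreadable from compound 1 to compound 3 is no larger than the usual scatter of the assay. Compound 3 is expected to give about 1.5 h in this assay, with a likely range from 0.6 h to 4 h, and a good chance that again only the limit is reported.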

Compound 3, half-life: 0.417 h
Beside the measured number, compound 3's estimate is 3.6-fold (0.56 log units) above it; the whole stated range lies above it.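

Putting piperidin-1-yl in place of (piperidin-1-yl)methyl gives an at least 2.3-fold lower number from compound 1 to compound 3 (0.37 log units; beyond the scatter) in this assay, so this single change on the chain is enough to separate two compounds that otherwise share the same core, and the position is clearly not indifferent to chain length. Compound 1 gives > 1 h, which is a limit and not a number. The step is therefore a minimum, and its full size cannot be read, yet compound 3 is the only compound shown with an actual number rather than a limit: the limit of > 1 h in this assay, at which 2 of the 3 values shown sit.

From the compounds shown here alone, it remains open whether a longer chain than that of compound 1 would stay at the limit or whether the reading would change again. Also open, going by these compounds, is whether a pyrrolidine or morpholine ring in place of the piperidine would give a similar result on the shorter chain of compound 3.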